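The source may hold more compounds than are shown below. What is called first, only, known or untested is meant among the compounds shown, and "the series" means these compounds.

Compound 1 `CCC1(Cc2ccccc2)OS(=O)(=O)C=C1OCC(=O)OC` in an ADME assay on HEL cells (Homo sapiens) for cytotoxicity, with a stated time of 3 days (a higher number here means that more compound is tolerated, a lower number that less compound is tolerated), gives > 200000 nM, which is a limit of the assay and not a number.
Compound 2 `O=S1(=O)C=C(OCc2ccccc2)C(Cc2ccccc2)(Cc2ccccc2)O1` gives 200000 nM.
Compound 3 `CCC1(Cc2ccccc2)OS(=O)(=O)C=C1OCc1ccc(OC)cc1` gives > 200000 nM, again a limit rather than a number.

Among the compounds with values here, compound 2 therefore stands as the only true number among the three, while the other two sit at the limit of > 200000 nM in this assay, at which 2 of the 3 values shown sit. Compound 4 `CCCC1(Cc2ccccc2)OS(=O)(=O)C=C1OCc1ccccc1` differs from compound 2 by ethyl in place of phenyl on a saturated chain carbon bound to a saturated ring carbon. Within the data shown here, the one measured step, a step that the two limits leave unreadable from compound 1 to compound 3, concerns a different part of the shared core and is unreadable in size, so it offers no guide to this change. With no readable step and all three values gathered at or on the same limit, I expect no step beyond the usual scatter: no change at the digits printed from compound 2 to compound 4 (within the scatter). Compound 4 is thus estimated at 200000 nM, within a range of 100000 nM to 400000 nM.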

Compound 4, half-maximal cytotoxic concentration: 200000 nM
Compound 4: middle estimate and measured number agree at the digits printed; measured number inside the range.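

Putting ethyl in place of phenyl on a saturated chain carbon bound to a saturated ring carbon gives, in this assay, no change at the digits printed from compound 2 to compound 4 (within the scatter). Within the data shown here, the earlier step cannot be read, so this is the first readable step, and it shows that the value holds when the aromatic ring at this position gives way to ethyl. It is still a narrow view, as many values stop at a limit of the assay: the limit of > 200000 nM in this assay, at which 2 of the 4 values shown sit.

As far as these compounds go, whether an amine or a carboxylic acid at this position would leave the value unchanged stays open. So does the effect of a longer chain there.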